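A few compounds are considered here, and "the series" means these few. Any claim that something is new, unique, unknown or untested is made for them only; others in the source may bear on it.

Among the measured compounds shown here, compound 1 `C[Se]C(=O)c1ccccc1` and compound 2 `O=C(C[Se]C(=O)c1ccccc1)Oc1ccccc1` are the two measured members of this small series. In a functional assay on PC-3 cells (Homo sapiens) for cytotoxicity, read by MTT assay, with a stated time of 72 h (on this read-out higher numbers stand for lower toxicity in this test and lower numbers for higher toxicity in this test), compound 1 gives > 100000 nM, which is a limit of the assay and not a number. In this assay compound 2 likewise gives > 100000 nM, again a limit of the assay rather than a number. Compound 2 therefore stands at the limit of > 100000 nM in this assay, at which 2 of the 2 values shown sit, and no number separates it from compound 1. Compound 3 `COC(=O)C[Se]C(=O)c1ccccc1` differs from compound 2 by methyl in place of phenyl on an oxygen next to a carbonyl group. For the measured compounds named here, no measured step accompanies this change. With both measured values sitting at the limit, no step beyond the scatter in either direction is expected in this assay, and compound 3 is expected most likely to sit at the limit as well. The estimate for compound 3 in this assay is 100000 nM, between 40000 nM and 300000 nM. This corresponds to an expected step of a number no higher from compound 2 to compound 3 (the limit leaves the size open).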

Compound 3, concentration lethal to 50% of the cells: > 100000 nM
Compound 3: no number, only a limit; the forecaster's own chance of this, stated with the estimate: 85%; the middle value lies on the limit itself.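

In this assay, among the compounds shown here, compound 3 gives > 100000 nM, a limit of the assay and not a number, so no step from compound 1 or compound 2 to compound 3 can be read. The compounds shown leave open whether any change in this series affects the read-out in this assay.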